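The compounds below may be only part of what the source reports. "The series", "measured", "known", "first", "only" and "open" are said of these compounds alone.

Measured compounds and their results:

- compound 1 `COc1cc(-c2nnc3n2NC(c2ccco2)C(C(=O)c2ccccc2C)S3)cc(OC)c1OC` — 69900 nM
- compound 2 `COc1cc(-c2nnc3n2NC(c2ccco2)C(C(=O)c2ccc(Br)cc2)S3)cc(OC)c1OC` — a limit of the assay, > 100000 nM
- compound 3 `COc1cc(-c2nnc3n2NC(c2cccs2)C(C(=O)c2ccc(C)cc2)S3)cc(OC)c1OC` — 28400 nM

All three share one core and were tested in a functional assay on MCF7 cells (Homo sapiens) for cytotoxicity, read by MTT assay, with a stated time of 48 h; a higher number here means a weaker inhibitor, a lower number a stronger inhibitor. Compound 1 gives 69900 nM, and compound 3 gives 28400 nM; these two differ in two places at once, so their values are simply set side by side. For compound 2 the result is a limit of the assay, > 100000 nM, at which (the limit of > 100000 nM in this assay, at which 1 of the 3 values shown sits). Compound 2 thus stands at the weak end of what the numbers show, with no exact figure of its own.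

The new compound 4 `COc1cc(-c2nnc3n2NC(c2ccco2)C(C(=O)C2CC2)S3)cc(OC)c1OC` differs from compound 2 in one place: cyclopropyl in place of 4-bromophenyl on a carbonyl carbon. Among the measured compounds shown here, only one measured step touches this position, the change from 2-methylphenyl to 4-bromophenyl, which gave an at least 1.4-fold higher number from compound 1 to compound 2 (0.15 log units; that floor lies within the scatter). For the measured compounds named here, no measured step swaps an aromatic ring for a small saturated ring here, so the direction is uncertain. The group being removed sits on a compound at the limit, and a move in either direction is plausible. Compound 4 is therefore expected to give 70000 nM, within 25000 nM to 200000 nM, which means an expected step of an at least 1.4-fold lower number from compound 2 to compound 4 (0.15 log units; that floor lies within the scatter) from compound 2 to compound 4, with a real chance that this assay again reports only a limit.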

Compound 4, half-maximal inhibitory concentration: > 100000 nM
Compound 4: no number, only a limit; the forecaster's own chance of this, stated with the estimate: 40%; at least 1.4-fold (0.15 log units) between middle value and limit.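

In this assay, compound 4 gives > 100000 nM, which is a limit of the assay and not a number. Replacing 2-methylphenyl with cyclopropyl, a three-membered non-aromatic ring, on a carbonyl carbon gives an at least 1.4-fold higher number from compound 1 to compound 4 (0.15 log units; that floor lies within the scatter), so this first non-aromatic group at the position brings no measurable gain over the aromatic groups, although the size of the step cannot be told apart from ordinary scatter. The step between compound 2 and compound 4 cannot be read, so 4-bromophenyl and cyclopropyl cannot be ranked against each other, and the two compounds now share the same ceiling: the limit of > 100000 nM in this assay, at which 2 of the 4 values shown sit.

On these data alone, what remains open is whether any group on this carbonyl carbon can give a clearly stronger result than compound 1 on this core, or whether the position simply has little room to improve the result. An amine or a carboxylic acid in place of cyclopropyl would test this with a very different kind of group, and any exact value from such a compound would be easier to compare than another limit.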